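Compound 3: phenethyl on the sulfur

The source may report more compounds than this note shows. Statements on the series, on what has been measured and on what is new or still open speak of the compounds shown alone.

Compound 1 `COc1ccc(SCc2ccc(/C=C/C(=O)Nc3ccccc3N)cc2)cc1OC`: 65.5%
Compound 2 `Cc1ccc(SCc2ccc(/C=C/C(=O)Nc3ccccc3N)cc2)cc1`: 43.4%

In a functional assay on A549 cells (Homo sapiens) for inhibition, read by CCK-8 assay, with a stated time of 72 h, tested at 2 uM (on this read-out higher numbers stand for more inhibition of growth at the one concentration tested and lower numbers for less inhibition of growth), compound 2 is the lower of the two measured compounds, at 43.4%, and compound 1 stands above it by more than the scatter. Next comes compound 3 `Nc1ccccc1NC(=O)/C=C/c1ccc(CSCCc2ccccc2)cc1`, which differs from compound 2 as follows: phenethyl in place of 4-methylphenyl on a sulfur. Among the measured compounds shown here, only one measured step bears on this change: a number 22.1 percentage points lower from compound 1 to compound 2 (beyond the scatter). That modest step also concerns the group on the sulfur, so this group can move the read-out. For the measured compounds named here, it gives no direction for phenethyl, however, since no measured compound carries that group. A step of that modest size is the widest expected, and no step beyond the scatter is the central expectation. The expected change is a number 0.4 percentage points lower from compound 2 to compound 3 (within the scatter). For compound 3 the estimated value is 43%, with an expected range from 21% to 65%.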

Compound 3, percent growth inhibition at one concentration: 45.7%
Estimate against measurement, compound 3: 2.7 percentage points below, and the stated range covers the measured number.
By their numbers in this assay, from the lowest: compounds 2 and 3 (each within the scatter of the next); then compound 1.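

In this assay, phenethyl in place of 4-methylphenyl on the sulfur gives a number 2.3 percentage points higher from compound 2 to compound 3 (within the scatter), so these two groups cannot be told apart at this position. Phenethyl in place of 3,4-dimethoxyphenyl gives a number 19.8 percentage points lower from compound 1 to compound 3 (beyond the scatter), so compound 1 now stands clear of two different sulfur substituents rather than one. No measurement at hand bears on the reason for these numbers.

The compounds shown leave open whether the higher number of compound 1 rests on the two methoxy groups together or on one alone, which 4-methoxyphenyl or 3-methoxyphenyl on the sulfur would address. Also open, on these data alone, is how the position responds to a benzyl group, a longer chain, or a chain ending in an amine or a carboxylic acid.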